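A Larger Aromatic Group in Place of Compound 2's Side Group

The compounds below may be only part of what the source reports. "The series", "measured", "known", "first", "only" and "open" are said of these compounds alone.

Compound 1 `CO/N=C(\C)CN1CCN(c2c(F)cc3c(=O)c(C(=O)O)cn(C4CC4)c3c2OC)CC1C`: 49.6 ug/mL
Compound 2 `COc1c(N2CCN(C/C(C)=N/NC(C)=O)C(C)C2)c(F)cc2c(=O)c(C(=O)O)cn(C3CC3)c12`: 707 ug/mL

Both compounds were tested in an ADME assay on Vero cells (Chlorocebus sabaeus) for cytotoxicity, read by MTT assay, with a stated time of 72 h; on this read-out higher numbers stand for lower toxicity in this test and lower numbers for higher toxicity in this test. Compound 2 stands highest of the two at 707 ug/mL, and its nearest neighbour is compound 1 at 49.6 ug/mL. Among the measured compounds shown here, the only measured step, a 14-fold higher number from compound 1 to compound 2 (1.15 log units; beyond the scatter), came with acetamido in place of methoxy on a double-bonded nitrogen, and it is large and beyond the scatter.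

Compound 3 `COc1c(N2CCN(CC/C(C)=N/Nc3ccccc3)C(C)C2)c(F)cc2c(=O)c(C(=O)O)cn(C3CC3)c12` departs from compound 2 through (a group of 11 heavy atoms (9 carbon, 2 nitrogen; one six-membered aromatic ring of carbon only) in place of a group of 7 heavy atoms (4 carbon, 2 nitrogen, 1 oxygen; no ring), on a saturated chain carbon bound to an amine nitrogen in a ring). For the measured compounds named here, the acetamido group leaves with this change, so the single measured step, a 14-fold higher number from compound 1 to compound 2 (1.15 log units; beyond the scatter), bears on it, though only in part. Going by the values given here, the entering group, with its six-membered aromatic ring of carbon only, has no measured counterpart here. Much of the height of compound 2 is therefore expected to be lost, with wide uncertainty and a large step downward in this assay. The expected step is a 4.7-fold lower number from compound 2 to compound 3 (0.67 log units; beyond the scatter). For compound 3 the estimated value is 150 ug/mL, with an expected range of 40 ug/mL to 550 ug/mL.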

Compound 3, half-maximal cytotoxic concentration: 62.5 ug/mL
Estimate against measurement, compound 3: 2.4-fold (0.38 log units) above; the range from low to high includes it.
By their numbers in this assay, from the lowest: compounds 1 and 3 (each within the scatter of the next); then compound 2.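

In this assay the high number of compound 2 does not survive this exchange on a saturated chain carbon bound to an amine nitrogen in a ring: the step is an 11-fold lower number from compound 2 to compound 3 (1.05 log units; beyond the scatter) even though the leaving and entering groups carry the same counts of hydrogen-bond donors and acceptors. The other comparison gives a 1.3-fold higher number from compound 1 to compound 3 (0.10 log units; within the scatter) and so lies within the scatter, which means that a group with a six-membered aromatic ring of carbon only and a group with no ring stand level here, and that among these three compounds only compound 2 stands apart. Nothing available on these compounds gives a reason for either result.

The compounds shown leave open whether the high number of compound 2 belongs to the acetamido group alone or would also appear with a related group on that nitrogen, such as a propionamido or benzoyl group. They also leave open whether a pyridine ring or a carboxylic acid on the entering group would stay at the level of compound 3 or move toward that of compound 2.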